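A Methoxy Group on Compound 2

This account rests on a few compounds, and the source may have more. Where it says the series, first, only, none or still open, it means among the compounds named here.

Going by the values given here, in a functional assay on HL-60 cells (Homo sapiens) for antiproliferative activity, read by sulforhodamine B assay, with a stated time of 48 h (on this read-out higher numbers stand for weaker inhibition of growth and lower numbers for stronger inhibition of growth), only two compounds have been measured so far. Compound 1 `COc1ccc(S(=O)(=O)c2nc3ccccc3cc2/C=C/C(=O)NO)cc1` gives > 10000 nM, which is a limit of the assay and not a number. Among the compounds with values here, compound 2 `O=C(/C=C/c1cccc(S(=O)(=O)c2ccc3ccccc3n2)c1)NO` gives 290 nM, the only actual number available, so there is no second number to rank it against.

Compound 3 `COc1ccc2nc(S(=O)(=O)c3cccc(/C=C/C(=O)NO)c3)ccc2c1` departs from compound 2 by a single change, methoxy in place of hydrogen on an aromatic carbon. Within the data shown here, no measured pair differing in one place is available as a guide. In this assay, the step is therefore expected to be small, with no firm direction and possibly nothing beyond the usual scatter. The estimate amounts to an expected step of a 1.0-fold higher number from compound 2 to compound 3 (0.01 log units; within the scatter). For compound 3 the expected value is 300 nM, with an estimated range from 100 nM to 900 nM.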

Compound 3, concentration for 50% growth inhibition: 720 nM
Compound 3: the middle estimate sits 2.4-fold (0.38 log units) below what was measured, within the range that was stated.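

In this assay, methoxy in place of hydrogen on an aromatic carbon brings a 2.5-fold higher number from compound 2 to compound 3 (0.39 log units; beyond the scatter), so growth inhibition is modestly weaker with the group present. Going by these compounds alone, this is the first single-place comparison in the set, and it shows that a change on this carbon of the six-membered aromatic ring registers beyond the usual scatter, yet compound 3 still gives a real number. Compound 1 remains a limit and not a number, so it offers no second step to set beside this one: the limit of > 10000 nM in this assay, at which 1 of the 3 values shown sits.

One step at one position cannot show whether the oxygen or the methyl carries the shift. As far as these compounds go, whether a hydroxy group, an amine or a fluorine on the same carbon would move the number further, or back towards compound 2, remains open.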